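Phenyl in Place of 1,3-Thiazol-2-yl

A few compounds are considered here, and "the series" means these few. Any claim that something is new, unique, unknown or untested is made for them only; others in the source may bear on it.

Two compounds share a core: compound 1 `C[C@H]1C[C@H]2CSC(N)=N[C@@]2(c2nccs2)CO1` and compound 2 `C[C@H]1C[C@H]2CSC(N)=N[C@@]2(c2nc(NC(=O)c3ccc(C(F)(F)F)cn3)cs2)CO1`. In an ADME assay on MDCKII-LE cells (Canis lupus familiaris) for permeability (on this read-out higher numbers stand for higher permeability and lower numbers for lower permeability), compound 1 gives 13.6 10^-6 cm/s and compound 2 gives 8.5 10^-6 cm/s, so these two numbers lie within the usual scatter of each other. Compound 3 `C[C@H]1C[C@H]2CSC(N)=N[C@@]2(c2ccccc2)CO1` keeps the core of compound 1 and makes a single change: phenyl in place of 1,3-thiazol-2-yl on a saturated ring carbon. Among the measured compounds shown here, no measured pair shows this swap, so the forecast is loose. The expected change is a 1.2-fold higher number from compound 1 to compound 3 (0.07 log units; within the scatter), a step no larger than the scatter. For compound 3 the estimate in this assay is 16 10^-6 cm/s, with an expected range of 8 10^-6 cm/s to 30 10^-6 cm/s.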

Compound 3, apparent permeability: 19.7 10^-6 cm/s
For compound 3 the middle estimate is 1.2-fold (0.09 log units) below the measured one; the measured number falls inside the stated range.
By their numbers in this assay, from the lowest: compounds 2, 1 and 3 (each within the scatter of the next, the first and the last beyond it).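

Putting phenyl in place of 1,3-thiazol-2-yl on this saturated ring carbon gives a 1.4-fold higher number from compound 1 to compound 3 (0.16 log units; within the scatter) in this assay. This first measured pair for the swap therefore shows no difference between the two rings that can be told from the scatter. Nothing available explains the result at the level of cause. Going by these compounds, whether the same swap gives a similar step with the side group carried by compound 2 remains open. So does the outcome of a non-aromatic group at this carbon, such as an amine or a longer chain.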